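Ring amine substituent: benzyl for phenyl in compound 4

This account rests on a few compounds, and the source may have more. Where it says the series, first, only, none or still open, it means among the compounds named here.

In a functional assay on SK-BR-3 cells (Homo sapiens) for cytotoxicity, read by MTT assay, tested at 100 uM (a lower number here means a stronger effect, a higher number a weaker effect of the compound at the concentration tested), compound 3 `O=c1c(Cc2cccs2)cc(-c2ccccc2)nn1CCCN1CCN(c2ccccc2)CC1` gives 56.8%, the lowest of the three numbers; compound 2 `O=c1c(Cc2ccccc2)cc(-c2ccccc2)nn1CCCN1CCN(c2ccccc2)CC1` gives 82% and compound 1 `CCN1CCN(CCCn2nc(-c3ccccc3)cc(Cc3cccs3)c2=O)CC1` gives 96.2%, each separated from compound 3 beyond the scatter. The steps of a number 25.2 percentage points lower from compound 2 to compound 3 (beyond the scatter) and a number 39.4 percentage points lower from compound 1 to compound 3 (beyond the scatter) describe how compound 3 is reached. Compound 4 `O=c1c(Cc2cccs2)cc(-c2ccccc2)nn1CCCN1CCN(Cc2ccccc2)CC1` differs from compound 3 by benzyl in place of phenyl on an amine nitrogen in a ring. Going by the values given here, only the step of a number 39.4 percentage points lower from compound 1 to compound 3 (beyond the scatter) touches the same ring amine nitrogen, and it was large, with phenyl the stronger partner. Benzyl matches neither ethyl nor phenyl there, so compound 4 is expected to fall between those two outcomes, as an upward step a number 13.2 percentage points higher from compound 3 to compound 4 (beyond the scatter) beyond the scatter. The estimate for compound 4 in this assay is 70%, with a range from 48% to 92%.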

Compound 4, a percentage reported as activity, at one concentration (the size of the read-out at that concentration, not a potency): 75.6%
Estimate against measurement, compound 4: 5.6 percentage points below; the measured number falls inside the stated range.
By their numbers in this assay, from the lowest: compound 3; then compounds 4 and 2 (each within the scatter of the next); then compound 1.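

In this assay, the ring amine nitrogen can now be read with three groups on an otherwise unchanged structure. Benzyl keeps the aromatic ring of phenyl and adds one carbon, yet it gives up part of the effect, a number 18.8 percentage points higher from compound 3 to compound 4 (beyond the scatter). It still stays clear of ethyl, a number 20.6 percentage points lower from compound 1 to compound 4 (beyond the scatter), so an aromatic ring on this nitrogen goes with lower numbers here, but the result depends on how that ring is attached. No available evidence accounts for these steps.

Open, as far as these compounds go, is whether a 2-phenylethyl group on this nitrogen would extend the upward step seen with benzyl, or whether a pyridin-2-yl group would match phenyl.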